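Thioether amide series: oral inhibition read-out, next compound

The source may report more compounds than this note shows. Statements on the series, on what has been measured and on what is new or still open speak of the compounds shown alone.

compound 1 `COc1ccc(C2N=C(SCc3ccc(F)cc3)NC(C)=C2C(=O)Nc2ccc(F)cc2)cc1OC`: 15.4%
compound 2 `CC1=C(C(=O)Nc2ccc(F)cc2)C(c2ccc([N+](=O)[O-])cc2)N=C(SCc2ccc(Cl)cc2)N1`: 16.9%
compound 3 `CC1=C(C(=O)Nc2ccc([N+](=O)[O-])cc2)C(c2ccc(Br)cc2)N=C(SCc2ccccc2)N1`: 19.5%

All three measured compounds were run in a functional assay on the whole organism (artery, strain albino) with Rattus norvegicus as the target, with a stated time of 900 min, at a dose of 10 mg/kg by the oral route; on this read-out lower numbers stand for less inhibition and higher numbers for more inhibition at the one dose given (going by the name of the read-out). Compound 3 gives the highest of the three numbers, but compound 2, the nearest, and compound 1, the furthest, both lie within the scatter of compound 3. The three therefore sit at one level, and no order among them can be read from these numbers. For the measured compounds named here, no pair of the measured compounds differs in one place only, so no single structural change has a measured effect attached to it.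

Compound 4 `CC1=C(C(=O)Nc2ccc([N+](=O)[O-])cc2)C(c2ccc(Br)cc2)N=C(SCc2ccccc2Cl)N1` is the next compound to be measured. It differs from compound 3 in one place: chloro in place of hydrogen on an aromatic carbon. Nothing measured here shows what a chloro in place of hydrogen on an aromatic carbon does to this read-out; the measured compounds differ from one another in several places at once and share one level.

The step from compound 3 to compound 4 is expected to be a number 1.5 percentage points higher from compound 3 to compound 4 (within the scatter), that is, no step beyond the scatter. Nothing measured points in either direction. Compound 4 is estimated to give 21% in this assay, within a range from 8% to 34%.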

Compound 4, a percentage reported as inhibition, in the whole organism at one dose (the size of the read-out at that dose, not a potency): 4.1%
Compound 4: middle estimate off by 16.9 percentage points, on the high side; the measured number lies below the stated range.
By their numbers in this assay, from the lowest: compound 4; then compounds 1, 2 and 3 (each within the scatter of the next).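

In this assay, the change from benzylsulfanyl to (2-chlorobenzyl)sulfanyl gives a number 15.4 percentage points lower from compound 3 to compound 4 (beyond the scatter). For the compounds shown here, this is the first single change with a measured effect, and the first step beyond the scatter. The position on the six-membered aromatic ring, ortho to a large group, is therefore not indifferent to substitution at the one oral dose given: a single chloro in place of hydrogen, with the rest of the structure held as it is in compound 3, is enough to move the read-out downward. No measurement at hand speaks to the reason for this step.

The compounds shown leave open whether the drop belongs to chloro specifically or would follow any group at this place, such as fluoro, methyl or methoxy, and whether chloro at another place on the same ring would do the same. Also open, as far as these compounds go, is whether the step carries over to compounds with a different amide substituent or a different aryl group on the shared core, since it rests on this one pair alone.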